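Replacing the trifluoromethyl of compound 1 with pyrrolidinylsulfonyl

The compounds below may be only part of what the source reports. "The series", "measured", "known", "first", "only" and "open" are said of these compounds alone.

Measured so far:
Compound 1 `FC(F)(F)c1ccc(Nc2ncnc3sc(Nc4c(Cl)cccc4Cl)nc23)cc1` gives 3 nM in a functional assay on HEK293 cells for antagonist activity at transient receptor potential cation channel subfamily V member 1 (Rattus norvegicus), read by calcium flux; a higher number here means a weaker inhibitor, a lower number a stronger inhibitor.
Compound 2 `CS(=O)(=O)c1ccccc1Nc1nc2c(Nc3ccc(C(F)(F)F)cc3)ncnc2s1` gives 221 nM in this assay.

Compound 1 stands at the lowest of the two numbers. For the measured compounds named here, its only neighbour is compound 2, and the step between them is a 74-fold higher number from compound 1 to compound 2 (1.87 log units; beyond the scatter); that step alters the group on the other nitrogen of the shared core and leaves the trifluoromethyl side untouched.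

Compound 3 `O=S(=O)(c1ccc(Nc2ncnc3sc(Nc4c(Cl)cccc4Cl)nc23)cc1)N1CCCC1` is the next compound and differs from compound 1 by (pyrrolidin-1-yl)sulfonyl in place of trifluoromethyl on an aromatic carbon. No measured step touches this position, so the step from compound 1 to compound 2 informs the new change only in a general way: it shows that a change of an aryl substituent on this core can move the number a great deal, but in which direction a change at the trifluoromethyl site would move it is not shown. The expectation is therefore cautious: a step of a 5.0-fold higher number from compound 1 to compound 3 (0.70 log units; beyond the scatter) is estimated for compound 3, toward a somewhat higher number. Compound 3 is expected to give about 15 nM in this assay, with a range from 3 nM to 80 nM.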

Compound 3, half-maximal inhibitory concentration: 0.5 nM
Compound 3: the middle estimate sits 30-fold (1.48 log units) above what was measured; measured number below the stated range.
By their numbers in this assay, from the lowest: compound 3; then compound 1; then compound 2.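

For the compounds shown here, this is the first reading at the site on an aromatic carbon of a six-membered aromatic ring of carbon only, para to a large group. In this assay the step to (pyrrolidin-1-yl)sulfonyl from trifluoromethyl is a 6.0-fold lower number from compound 1 to compound 3 (0.78 log units; beyond the scatter), so the earlier question of direction now has one answer for this pair. The site accepts a group of 8 heavy atoms in place of 4, including one five-membered non-aromatic ring and 2 hydrogen-bond acceptors, without the number rising; no measurement available here bears on what lies behind the lower number.

Going by these compounds, a single replacement cannot separate the sulfonyl link from the pyrrolidine ring, so it remains open whether a smaller methylsulfonyl, an unsubstituted sulfonamide or a morpholine-bearing sulfonyl would give a similar number in this assay. Going by these compounds alone, it also remains open whether the lower number would carry over to the core of compound 2, with its 2-(methylsulfonyl)phenyl group, since no single-place step connects that compound with compound 3.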